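A few compounds are considered here, and "the series" means these few. Any claim that something is new, unique, unknown or untested is made for them only; others in the source may bear on it.

Within the data shown here, in a functional assay on Raji cells (Homo sapiens) for antiproliferative activity, read by MTT assay, with a stated time of 48 h (a higher number here means a weaker inhibitor, a lower number a stronger inhibitor), compound 2 `CCN(CC)CCCn1c(N)c(-c2nc3ccccc3[nH]2)c2nc(C#N)c(C#N)nc21` gives 1870 nM, the only actual number so far. Compound 1 `CCCn1c(N)c(-c2nc3ccccc3[nH]2)c2nc(C#N)c(C#N)nc21` reads > 50000 nM, which is a limit of the assay and not a number. Compound 3 `N#Cc1nc2c(-c3nc4ccccc4[nH]3)c(N)n(CCCO)c2nc1C#N` keeps the shared core but carries hydroxy in place of diethylamino on a saturated chain carbon, three bonds along the chain from an aromatic nitrogen, so that 3-(diethylamino)propyl becomes 3-hydroxypropyl. Among the measured compounds shown here, one measured step bears on this change, at the same place: an at least 26-fold lower number from compound 1 to compound 2 (1.42 log units; beyond the scatter), a large step that came with the arrival of diethylamino. Going by these compounds, compound 3 loses that group, so much of this gain is expected to be lost, although hydroxy itself is untested. A large move to a higher number in this assay is therefore expected. The estimated change is an 11-fold higher number from compound 2 to compound 3 (1.03 log units; beyond the scatter). Compound 3 is expected at 20000 nM, with an estimated range of 5000 nM to 50000 nM.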

Compound 3, half-maximal inhibitory concentration: > 50000 nM
Compound 3 ended at the assay's limit; the forecaster's own chance of this, stated with the estimate: 45%; middle value at least 2.5-fold (0.39 log units) from the limit.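

In this assay, the change from 3-(diethylamino)propyl to 3-hydroxypropyl gives an at least 26-fold higher number from compound 2 to compound 3 (1.42 log units; beyond the scatter), so the earlier gain over compound 1 does not carry over to hydroxy at this place, and among the compounds shown only diethylamino gives a value below the limit. Compound 3 reads > 50000 nM, which is a limit of the assay and not a number. The step from compound 2 to compound 3 therefore gives only a minimum size, and the step between compound 1 and compound 3 cannot be read: the limit of > 50000 nM in this assay, at which 2 of the 3 values shown sit.

The compounds shown leave open whether another amine, such as dimethylamino, or a carboxylic acid at the same place would keep the value of compound 2. They also leave open whether diethylamino on a shorter or a longer chain would do so.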